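The source may report more compounds than this note shows. Statements on the series, on what has been measured and on what is new or still open speak of the compounds shown alone.

Compound 1, `N#CC1(c2cc(CCO)cc(-c3ccnc4[nH]nc(C(F)(F)F)c34)c2)CC1`, in an assay on isolated protein for inhibition of protein kinase C epsilon type (Homo sapiens), read by coupled enzyme assay (a lower number here means a stronger inhibitor, a higher number a weaker inhibitor), gives 25 nM.
Compound 2, `C[C@H](O)Cc1cc(-c2ccnc3[nH]nc(C(F)(F)F)c23)cc(C2(C#N)CC2)c1`, in this assay gives 51 nM.
Compound 3, `CCC(O)Cc1cc(-c2ccnc3[nH]nc(C(F)(F)F)c23)cc(C2(C#N)CC2)c1`, in this assay gives 49 nM.

Compound 3 stands second highest of the three numbers in this assay. Its nearest neighbour is compound 2, and the step of a 1.0-fold lower number from compound 2 to compound 3 (0.02 log units; within the scatter) lies within the scatter; its furthest neighbour is compound 1, and the step of a 2.0-fold higher number from compound 1 to compound 3 (0.29 log units; within the scatter) also lies within the scatter. Compound 4, `COCC(O)Cc1cc(-c2ccnc3[nH]nc(C(F)(F)F)c23)cc(C2(C#N)CC2)c1`, differs from compound 3 by methoxy in place of methyl on a saturated chain carbon, two bonds along the chain from an oxygen on a saturated carbon. Among the measured compounds shown here, no measured step replaces a methyl with a methoxy. The steps that touch the same chain are a 2.0-fold higher number from compound 1 to compound 2 (0.31 log units; beyond the scatter) and a 2.0-fold higher number from compound 1 to compound 3 (0.29 log units; within the scatter), which put a methyl or an ethyl in place of a hydrogen, and a 1.0-fold lower number from compound 2 to compound 3 (0.02 log units; within the scatter), which exchanges 1-hydroxyethyl for 1-hydroxypropyl. All of these were modest or flat, and the one closest in kind to the present change was flat. In this assay the step of a 1.0-fold higher number from compound 3 to compound 4 (0.01 log units; within the scatter) is therefore expected to stay within the scatter, with no clear direction. Compound 4 is estimated at 50 nM, with a range from 25 nM to 100 nM.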

Compound 4, inhibition constant: 77 nM
For compound 4 the middle estimate is 1.5-fold (0.19 log units) below the measured one, within the range that was stated.
By their numbers in this assay, from the lowest: compounds 1, 3, 2 and 4 (each within the scatter of the next, the first and the last beyond it).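

In this assay, methoxy in place of methyl on a saturated chain carbon, two bonds along the chain from an oxygen on a saturated carbon, brings in an oxygen and one hydrogen-bond acceptor, which no earlier change at this chain did, yet a 1.6-fold higher number from compound 3 to compound 4 (0.20 log units; within the scatter) and a 1.5-fold higher number from compound 2 to compound 4 (0.18 log units; within the scatter) both leave compound 4 within the scatter of the alkyl-bearing compounds. Measured against the unbranched alcohol, however, a 3.1-fold higher number from compound 1 to compound 4 (0.49 log units; beyond the scatter) is the largest of the three steps from compound 1 and, though still modest, lies beyond the scatter, as a 2.0-fold higher number from compound 1 to compound 2 (0.31 log units; beyond the scatter) does, while a 2.0-fold higher number from compound 1 to compound 3 (0.29 log units; within the scatter) stays within it; all three substituents give a higher number than hydrogen, and none of the compounds shown goes against this. Nothing available here bears on why the numbers fall as they do.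

The compounds shown leave open whether an amine such as dimethylamino, a carboxylic acid or a longer ether chain in place of the methoxy would stay within the scatter of compound 4. They also leave open how the two mirror-image forms at the hydroxyl-bearing carbon of compound 4 compare.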